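Swapping fluorophenyl for dimethylphenyl on compound 3

The source may hold more compounds than are shown below. What is called first, only, known or untested is meant among the compounds shown, and "the series" means these compounds.

Compound 3 `Fc1ccc(C2=NN(C3=NC(c4ccccc4)CS3)C(c3ccc4ccccc4c3)C2)cc1` stands second highest of the three numbers in a functional assay on BGC-823 cells (Homo sapiens) for inhibition, read by CCK-8 assay, with a stated time of 48 h (a lower number here means a stronger inhibitor, a higher number a weaker inhibitor), where compound 3 gives 17300 nM. Within the data shown here, its nearest neighbour is compound 1 `Fc1ccc(C2=NN(C3=NC(c4ccccc4)CS3)C(c3cccc4ccccc34)C2)cc1`, which gives 22700 nM; the one single-change step, a 1.3-fold lower number from compound 1 to compound 3 (0.12 log units; within the scatter), lies within the scatter. Compound 2 `Cc1ccc(C2=NN(C3=NC(=O)CS3)C(c3ccc4ccccc4c3)C2)cc1` gives 7790 nM, beyond the scatter from compound 3, but compound 2 differs from compound 3 in more than one place, so its value offers no single-change reading. Compound 4 `Cc1ccc(C2=NN(C3=NC(c4ccccc4)CS3)C(c3ccc4ccccc4c3)C2)cc1C` arises from compound 3 by the change (3,4-dimethylphenyl in place of 4-fluorophenyl on a carbon with a double bond to nitrogen). Among the measured compounds shown here, no measured step touches this change, and the only measured step, which concerns a different change, was within the scatter, so the expected step of a 1.1-fold lower number from compound 3 to compound 4 (0.03 log units; within the scatter) is none beyond the scatter. Compound 4 is therefore estimated at 16000 nM, within the range 6000 nM to 45000 nM.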

Compound 4, half-maximal inhibitory concentration: 6570 nM
Compound 4: the middle estimate sits 2.4-fold (0.39 log units) above what was measured; measured number inside the range.
By their numbers in this assay, from the lowest: compounds 4 and 2 (each within the scatter of the next); then compounds 3 and 1 (each within the scatter of the next).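

In this assay, the group on the carbon with a double bond to nitrogen proves able to shift the number: 3,4-dimethylphenyl in place of 4-fluorophenyl gives a 2.6-fold lower number from compound 3 to compound 4 (0.42 log units; beyond the scatter), a modest step. Among these compounds, this is the first single change here to pass beyond the scatter, whereas the naphthalen-2-yl for naphthalen-1-yl change (a 1.3-fold lower number from compound 1 to compound 3 (0.12 log units; within the scatter)) stayed within it. Nothing measured here accounts for the step. On these data alone, whether a single methyl would give the same step remains open, as does how a methoxy group or an amine on this phenyl ring would read.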